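Bromo in place of chloro: notes on the series

A few compounds are considered here, and "the series" means these few. Any claim that something is new, unique, unknown or untested is made for them only; others in the source may bear on it.

Measured in a functional assay on L1210 cells (Mus musculus) for inhibition; on this read-out lower numbers stand for stronger inhibition and higher numbers for weaker inhibition:
compound 1 `O=C1CCCCC/C1=C\c1ccccc1`: 261000 nM
compound 2 `O=C1CCCCC/C1=C\c1cccc(F)c1`: 382000 nM
compound 3 `O=C1CCCCC/C1=C\c1cccc(Cl)c1`: 144000 nM

Compound 3 stands at 144000 nM, the lowest number of the three, though not clearly separated from all of them. The measured steps are small: a 1.8-fold lower number from compound 1 to compound 3 (0.26 log units; within the scatter) and a 1.5-fold higher number from compound 1 to compound 2 (0.17 log units; within the scatter) stay within the scatter, and only a 2.7-fold lower number from compound 2 to compound 3 (0.42 log units; beyond the scatter) passes it, modestly.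

Compound 4 `O=C1CCCCC/C1=C\c1cccc(Br)c1` has bromo in place of chloro on an aromatic carbon. With steps of this size, no shift beyond the scatter is expected in this assay, and any drift would more likely be downward. The expected step is a 1.2-fold lower number from compound 3 to compound 4 (0.08 log units; within the scatter). Compound 4 is estimated at 120000 nM, with an expected range of 60000 nM to 260000 nM.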

Compound 4, half-maximal inhibitory concentration: 246000 nM
Beside the measured number, compound 4's estimate is 2.1-fold (0.31 log units) below it, and the stated range covers the measured number.
By their numbers in this assay, from the lowest: compounds 3, 4, 1 and 2 (each within the scatter of the next, the first and the last beyond it).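

In this assay, bromo on this aromatic carbon lands within the scatter of all three other compounds (a 1.7-fold higher number from compound 3 to compound 4 (0.23 log units; within the scatter)) (a 1.6-fold lower number from compound 2 to compound 4 (0.19 log units; within the scatter)) (a 1.1-fold lower number from compound 1 to compound 4 (0.03 log units; within the scatter)). For the compounds shown here, the one separation beyond the scatter, chloro against fluoro, therefore has no counterpart with bromo, and hydrogen and the three halogens otherwise cannot be told apart at this place. No evidence on hand bears on this result.

From the compounds shown here alone, whether an amine or a carboxylic acid on this aromatic carbon would leave the scatter remains open. So does the outcome of either group in other places on the shared core.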